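Replacing 1-acetamidoethyl with pyridazin-4-yl in compound 3

This account rests on a few compounds, and the source may have more. Where it says the series, first, only, none or still open, it means among the compounds named here.

In a physicochemical assay for solubility, measured as kinetic solubility, with a stated time of 1 h, at pH 7.4 (a lower number here means a less soluble compound, a higher number a more soluble compound), compound 1 (`CS(=O)(=O)Nc1nc(-c2ccc(Cl)c(Cl)c2)cs1`) gives the highest of three numbers, 429000 nM, and compound 2 (`CC(=O)Nc1nc(-c2cccc(Cl)c2)cs1`) gives the lowest, 2000 nM. Compound 3 (`CC(=O)N[C@@H](C)C(=O)NC1=NN(c2ccc(Cl)c(Cl)c2)CC1`) stands second at 58000 nM, clearly separated from both. Compound 4 (`O=C(NC1=NN(c2ccc(Cl)c(Cl)c2)CC1)c1ccnnc1`) carries pyridazin-4-yl in place of 1-acetamidoethyl on a carbonyl carbon. For the measured compounds named here, no measured pair of compounds shows a change of this kind, so the data offer no direct precedent. The expected change in this assay is therefore only a small fall, and the estimated step is a 1.9-fold lower number from compound 3 to compound 4 (0.29 log units; within the scatter). For compound 4 the estimate is 30000 nM, with an expected range of 7000 nM to 120000 nM.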

Compound 4, solubility: 23000 nM
For compound 4 the middle estimate is 1.3-fold (0.12 log units) above the measured one; the measured number falls inside the stated range.
By their numbers in this assay, from the lowest: compound 2; then compound 4; then compound 3; then compound 1.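

For the compounds shown here, the first step at this position shows that, in this assay, pyridazin-4-yl in place of 1-acetamidoethyl on a carbonyl carbon costs only a modest amount (a 2.5-fold lower number from compound 3 to compound 4 (0.40 log units; beyond the scatter)). This single change removes the defined stereocentre and the hydrogen-bond donor of the group that leaves, and it brings in an aromatic ring, yet the step stays modest. Nothing available explains the step.

The pair cannot separate these features from one another. On these data alone, how a carboxylic acid, an amine or a longer chain on this carbonyl carbon would compare also remains open.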